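Taking one methoxy from compound 3

The source may report more compounds than this note shows. Statements on the series, on what has been measured and on what is new or still open speak of the compounds shown alone.

Compound 1 `COc1ccc(/C=C/c2cc(C)no2)cc1OC` reaches only the limit > 100000 nM in a functional assay on PC-3 cells (Homo sapiens) for cytotoxicity, read by MTT assay, with a stated time of 72 h (a higher number here means a weaker inhibitor, a lower number a stronger inhibitor), and gives no exact number. Compound 2 `COc1cc(/C=C/c2cc(C)[nH]n2)ccc1O` gives 16500 nM and compound 3 `COc1ccc(/C=C/C(=O)CC(C)=O)cc1OC` gives 8900 nM in this assay and these two numbers lie within the scatter of each other. Compound 4 `COc1ccc(/C=C/C(=O)CC(C)=O)cc1` differs from compound 3 by hydrogen in place of methoxy on an aromatic carbon and has yet to be measured. Within the data shown here, the only measured step of an at least 11-fold lower number from compound 1 to compound 3 (1.05 log units; beyond the scatter) is large but lies at another place and leaves this methoxy untouched. Among the measured compounds shown here, with no measured step at this place, the expected step in this assay is a 1.1-fold higher number from compound 3 to compound 4 (0.05 log units; within the scatter) and stays within the scatter. The estimate for compound 4 is 10000 nM within a range of 3500 nM to 30000 nM.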

Compound 4, half-maximal inhibitory concentration: 15800 nM
For compound 4 the middle estimate is 1.6-fold (0.20 log units) below the measured one, within the range that was stated.
By their numbers in this assay, from the lowest: compounds 3, 4 and 2 (each within the scatter of the next). At a limit, above all of these: compound 1.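

In this assay this position now has a measured step, a 1.8-fold higher number from compound 3 to compound 4 (0.25 log units; within the scatter), the only one that touches this methoxy. Hydrogen can therefore stand in place of the methoxy ortho to a methoxy group while the two numbers stay within the scatter of each other, so in this pair that methoxy is not needed to retain the measured cytotoxicity. Nothing measured here bears on why this is so.

From the compounds shown here alone, whether an amine or a longer ether chain at this position would move the number beyond the scatter remains open. So does the effect of the same swap in the core of compound 1.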